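The source may hold more compounds than are shown below. What is called first, only, known or untested is meant among the compounds shown, and "the series" means these compounds.

Compound 2, the structure `N/C(=N\NC(=S)N1CCSCC1)c1ccccn1`, is the starting point of this step. In a functional assay on MCF7 cells (Homo sapiens) for cytotoxicity, read by MTT assay, with a stated time of 72 h, tested at 3 uM (a lower number here means less inhibition of growth, a higher number more inhibition of growth at the concentration tested), compound 2 gives 29%, and that number is within the scatter of its two measured companions: compound 1, the structure `Cc1ccnc(/C(N)=N/NC(=S)N2CCSCC2)c1`, which in this assay gives 33.8%, and compound 3, the structure `Cc1ccnc(/C(N)=N/NC(=S)N2CCCCCC2)c1`, which in this assay gives 36.3%. Within the data shown here, the only change measured in one place is a number 4.8 percentage points lower from compound 1 to compound 2 (within the scatter), a hydrogen in place of a methyl on an aromatic carbon, and it does not bear on the ring attached to the thiocarbonyl carbon.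

The unmeasured compound 4 is the structure `N/C(=N\NC(=S)N1CCCC1)c1ccccn1`. Its change from compound 2 is pyrrolidin-1-yl in place of thiomorpholin-4-yl on a thiocarbonyl carbon. Among the measured compounds shown here, no measured step exchanges one such ring for another, so the closest guide is the pair of compounds 1 and 3, which carry different rings on the thiocarbonyl carbon and whose two numbers lie within the scatter of each other. On that basis, and because the step of a number 4.8 percentage points lower from compound 1 to compound 2 (within the scatter) shows how little the series has moved, compound 4 is expected to show no step beyond the scatter in this assay: the estimated step of a number 1 percentage points higher from compound 2 to compound 4 (within the scatter) is small. Compound 4 is therefore estimated at 30%, within a range of 18% to 42%.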

Compound 4, percent growth inhibition at one concentration: 49.8%
Estimate against measurement, compound 4: 19.8 percentage points below; the whole stated range lies below it.
By their numbers in this assay, from the lowest: compounds 2, 1 and 3 (each within the scatter of the next); then compound 4.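

In this assay, among these compounds, pyrrolidin-1-yl in place of thiomorpholin-4-yl on a thiocarbonyl carbon gives a number 20.8 percentage points higher from compound 2 to compound 4 (beyond the scatter), the only step in this set that lies beyond the scatter. It shows that the group on this carbon can move the number, which compound 1 and compound 3, with their different rings and numbers within the scatter of each other, did not show. The compounds shown offer no measurement that accounts for this step.

On these data alone, the exchange alters ring size and removes the sulfur in one step, and pyrrolidin-1-yl stands here only on the core of compound 2, so it remains open which of those two differences matters and whether the step carries over to the methyl-bearing core of compound 1. Piperidin-1-yl, morpholin-4-yl or an open-chain dimethylamino group on the same thiocarbonyl carbon would be the next groups to bear on these questions.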